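This account rests on a few compounds, and the source may have more. Where it says the series, first, only, none or still open, it means among the compounds named here.

Measured compounds in a functional assay (trachea) with Rattus norvegicus as the target; on this read-out lower numbers stand for lower potency and higher numbers for higher potency (the scale is a negative logarithm):
compound 1 `COc1ccc2c(c1)C(n1ccccc1=O)=CC(C)(C)O2` gives 5.99
compound 2 `CC1(C)C=C(n2ccccc2=O)c2cc(O)ccc2O1` gives 5.31
compound 3 `CC1(C)C=C(n2ccccc2=O)c2cc(OC(=O)Nc3ccccc3)ccc2O1` gives 4.89

Compound 3 stands lowest of the three numbers in this assay; its nearest neighbour is compound 2, and compound 1 is the furthest away. The three measured steps all concern what sits on the aromatic oxygen of the shared core: a number 0.68 log units lower from compound 1 to compound 2 (beyond the scatter), a number 1.10 log units lower from compound 1 to compound 3 (beyond the scatter) and a number 0.42 log units lower from compound 2 to compound 3 (beyond the scatter). Each of them is a change at that oxygen, and each lowers the number.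

Compound 4 `CC1(C)C=C(n2ccccc2=O)c2cc(OC(=O)Nc3ccc(F)cc3)ccc2O1` is not yet measured. It differs from compound 3 in this way: fluoro in place of hydrogen on an aromatic carbon. Going by the values given here, none of the measured steps touches the phenyl of the phenylcarbamoyl group, so no measured step bears directly on this change. With the substituent on the aromatic oxygen kept as in compound 3, the expectation for compound 4 is a step of a number 0.01 log units higher from compound 3 to compound 4 (within the scatter), that is, no change beyond the scatter. Compound 4 is therefore expected to give about 4.9 in this assay, with a range from 4.4 to 5.4.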

Compound 4, logarithm of the reciprocal of the active concentration, log(1/C): 4.37
For compound 4 the middle estimate is 0.53 log units above the measured one, outside the stated range (below it).
By their numbers in this assay, from the lowest: compound 4; then compound 3; then compound 2; then compound 1.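

Notes on the series: the phenyl of the phenylcarbamoyl group is not a silent part of these compounds, since in this assay fluoro in place of hydrogen, para to a large group, gives a number 0.52 log units lower from compound 3 to compound 4 (beyond the scatter) and so moves the number beyond the scatter. The (4-fluorophenyl)carbamoyl group continues the downward trend at the aromatic oxygen, with a number 0.94 log units lower from compound 2 to compound 4 (beyond the scatter) against hydrogen on that oxygen and a number 1.62 log units lower from compound 1 to compound 4 (beyond the scatter) against methyl there. Nothing on hand explains this drop.

Open, going by these compounds, is whether the step belongs to fluoro alone or would also follow chloro, methyl, methoxy or an amine at the same place on this ring. Also open, on these data alone, is how a carboxylic acid on this phenyl, or a longer chain in place of methyl on the aromatic oxygen, would read in this assay on this shared core.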